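From ethyl(methyl)amino to propylamino on a shared core

A few compounds are considered here, and "the series" means these few. Any claim that something is new, unique, unknown or untested is made for them only; others in the source may bear on it.

Compound 1 `CN(C)C(=O)/C=C1\CCc2ccc(F)cc21`: > 100 mg/kg, a limit
Compound 2 `O=C(/C=C1\CCc2ccc(F)cc21)NC1CCC1`: > 100 mg/kg, a limit
Compound 3 `CCN(C)C(=O)/C=C1\CCc2ccc(F)cc21`: 100 mg/kg

Within the data shown here, in a functional assay on the whole organism with Mus musculus as the target (a lower number here means that less compound is needed, a higher number that more compound is needed for the effect), compound 3 gives 100 mg/kg, the only true number in the set. The other two values mark (the limit of > 100 mg/kg in this assay, at which 2 of the 3 values shown sit).

Compound 4 `CCCNC(=O)/C=C1\CCc2ccc(F)cc21` carries propylamino in place of ethyl(methyl)amino on a carbonyl carbon.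

Among the measured compounds shown here, three measured steps touch this same place, and none has a readable size. They are a number no higher from compound 1 to compound 3 (the limit leaves the size open), a number no higher from compound 2 to compound 3 (the limit leaves the size open) and a step that the two limits leave unreadable from compound 1 to compound 2. For the measured compounds named here, compound 2 is the only measured compound that keeps the amide hydrogen, and it gives > 100 mg/kg, a limit. That single case tilts the expectation slightly toward a higher number, but no step beyond the scatter is expected in this assay. The expected step is a 1.2-fold higher number from compound 3 to compound 4 (0.08 log units; within the scatter). Compound 4 is estimated at 120 mg/kg, with an expected range from 50 mg/kg to 300 mg/kg.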

Compound 4, dose for half-maximal effect: > 100 mg/kg
Compound 4: only a limit was reported (the forecaster's own chance of this, stated with the estimate: 55%); the middle value does not contradict the limit.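

In this assay compound 4 gives > 100 mg/kg, which is a limit. Exchanging ethyl(methyl)amino, with no hydrogen-bond donor, for propylamino, with one, leaves the same heavy-atom count and gives a number no lower from compound 3 to compound 4 (the limit leaves the size open); the steps from compound 1 and compound 2 to compound 4 cannot be read. Compound 2 and compound 4, the two that keep the amide hydrogen, both lack a true number, but so does compound 1, which has none, so the amide hydrogen alone does not separate them from compound 3, and the set gathers at one end of the scale: the limit of > 100 mg/kg in this assay, at which 3 of the 4 values shown sit.

On these data alone, how far compound 4 lies past the limit stays open. So does whether diethylamino or a pyrrolidine amide on the carbonyl carbon would give a true number.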